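The compounds below may be only part of what the source reports. "The series", "measured", "known", "first", "only" and "open" are said of these compounds alone.

Compound 1 `c1ccc(-c2cn3ccnc3c(-c3ccc4ncn(C5CCCCC5)c4c3)n2)cc1` and compound 2 `COc1ccc(-c2cn3ccnc3c(-c3ccc4ncn(C5CCCCC5)c4c3)n2)cc1` share one core and differ only by a methoxy in place of hydrogen on an aromatic carbon. Going by the values given here, in a functional assay on MOLT-4 cells (Homo sapiens) for inhibition, read by sulforhodamine B assay, with a stated time of 48 h, tested at 10 uM (a lower number here means less inhibition, a higher number more inhibition at the concentration tested (going by the name of the read-out)), compound 1 gives 67.7%, the lowest of the two numbers measured so far, and compound 2 gives 82.8%; the step of a number 15.1 percentage points higher from compound 1 to compound 2 (beyond the scatter) is the only one measured. Compound 3 `Clc1ccc(-c2cn3ccnc3c(-c3ccc4ncn(C5CCCCC5)c4c3)n2)cc1` differs from compound 1 by chloro in place of hydrogen on an aromatic carbon. Among the compounds with values here, the methoxy step bears on this only loosely, since no measured step exchanges hydrogen for chloro. The step is expected to be a number 4.3 percentage points higher from compound 1 to compound 3 (within the scatter), a small rise or none beyond the scatter. Compound 3 is estimated at 72%, between 52% and 90%.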

Compound 3, a percentage reported as inhibition, at one concentration (the size of the read-out at that concentration, not a potency): 8.87%
Beside the measured number, compound 3's estimate is 63.1 percentage points above it; measured number outside the range, below it.
By their numbers in this assay, from the lowest: compound 3; then compound 1; then compound 2.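

In this assay this position proves highly sensitive to what it carries: phenyl to 4-chlorophenyl gives a number 58.8 percentage points lower from compound 1 to compound 3 (beyond the scatter), and chloro in place of methoxy gives a number 73.9 percentage points lower from compound 2 to compound 3 (beyond the scatter). Methoxy and chloro thus move the read-out in opposite directions from hydrogen at the same place, so the rise with methoxy does not carry over to chloro. Nothing available here accounts for the fall. From the compounds shown here alone, whether the loss is particular to chloro or also appears with fluoro, bromo or methyl remains open. So does whether an amine or a carboxylic acid at this place would follow methoxy or chloro.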